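Series notes: the step from compound 3 to compound 4

The source may hold more compounds than are shown below. What is called first, only, known or untested is meant among the compounds shown, and "the series" means these compounds.

In a functional assay on MCF7 cells (Homo sapiens) for inhibition, read by MTT assay, with a stated time of 72 h (on this read-out higher numbers stand for weaker inhibition and lower numbers for stronger inhibition), compound 1 `COc1cc(NC(C)CCCNC(=O)NNC(=O)Nc2ccc(Cl)cc2)c2ncccc2c1` gives 180 nM, compound 2 `COc1cc(NC(C)CCCNC(=O)NNC(=O)Nc2ccc(C(F)(F)F)cc2)c2ncccc2c1` gives 100 nM and compound 3 `COc1cc(NC(C)CCCNC(=O)NNC(=O)Nc2ccc(Br)cc2)c2ncccc2c1` gives 100 nM. Compound 3 stands level with compound 2, and all three numbers lie within the scatter of one another.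

Compound 4 `COc1cc(NC(C)CCCNC(=O)Nc2ccc(O)cc2)c2ncccc2c1` departs much further from compound 3: 4-hydroxyphenyl in place of ((4-bromophenyl)carbamoyl)amino on an amide-type nitrogen. Three measured steps are available, and all concern one substituent on an aromatic carbon. Trifluoromethyl in place of chloro gives a 1.8-fold lower number from compound 1 to compound 2 (0.26 log units; within the scatter), bromo in place of chloro gives a 1.8-fold lower number from compound 1 to compound 3 (0.26 log units; within the scatter), and bromo in place of trifluoromethyl gives no change at the digits printed from compound 2 to compound 3 (within the scatter). These steps bear only weakly on the change at hand. None of them removes the ((4-bromophenyl)carbamoyl)amino group or introduces 4-hydroxyphenyl, so the series offers no direct measure of this step. The flat picture holds only for compounds 1, 2 and 3. With so large a change from compound 3 at 100 nM, a move to a higher number is the cautious expectation, though with little support from the data. The step expected in this assay is a 10-fold higher number from compound 3 to compound 4 (1.00 log units; beyond the scatter), beyond the scatter. For compound 4 the estimated value is 1000 nM, with an expected range of 120 nM to 10000 nM.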

Compound 4, half-maximal inhibitory concentration: 5200 nM
Beside the measured number, compound 4's estimate is 5.2-fold (0.72 log units) below it; measured number inside the range.
By their numbers in this assay, from the lowest: compounds 2, 3 and 1 (each within the scatter of the next); then compound 4.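

In this assay, changing only the substituent on the aromatic carbon left every number within the scatter, but replacing the whole terminal group on the amide-type nitrogen gives a 52-fold higher number from compound 3 to compound 4 (1.72 log units; beyond the scatter), and the matching replacement of ((4-chlorophenyl)carbamoyl)amino gives a 29-fold higher number from compound 1 to compound 4 (1.46 log units; beyond the scatter). The flat picture among compounds 1, 2 and 3 therefore does not extend to this position: both steps are large and beyond the scatter, so the loss of inhibition is seen from two separate starting points. No measured information on this series accounts for the rise in the number.

The compounds shown leave open which part of the exchange carries the loss, since the step from ((4-bromophenyl)carbamoyl)amino to 4-hydroxyphenyl both shortens the group and puts hydroxy in place of the halogen on the ring. A 4-bromophenyl group on the amide-type nitrogen or a ((4-hydroxyphenyl)carbamoyl)amino group would separate these two changes, and a 4-aminophenyl group would show whether the result is particular to hydroxy.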